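The source may report more compounds than this note shows. Statements on the series, on what has been measured and on what is new or still open speak of the compounds shown alone.

Compound 1 `Cc1ccnc(-c2ccccc2OCC2=NCCN2)c1` — < 100000 nM
Compound 2 `c1ccc(-c2ccoc2)c(OCC2=NCCN2)c1` — 0.501 nM

In a functional assay for activation of Alpha-1A adrenergic receptor (Homo sapiens), read by calcium flux (on this read-out higher numbers stand for an effect only at larger amounts of compound and lower numbers for an effect already at smaller amounts), compound 1 gives < 100000 nM, which is a limit of the assay rather than a number (the limit of < 100000 nM in this assay, at which 1 of the 2 values shown sits). Compound 2 gives 0.501 nM in this assay, the only number shown, so no measured step can be drawn between the two. Compound 3 `Cc1csc(-c2ccccc2OCC2=NCCN2)n1` differs from compound 2 by 4-methyl-1,3-thiazol-2-yl in place of furan-3-yl on an aromatic carbon. Among the measured compounds shown here, with no step between measured compounds to lean on, the expectation for compound 3 is a loss in this assay, a 60-fold higher number from compound 2 to compound 3 (1.78 log units; beyond the scatter), beyond the scatter. Compound 3 is estimated at 30 nM, within 2 nM to 500 nM.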

Compound 3, half-maximal effective concentration: 25.1 nM
Compound 3: the middle estimate sits 1.2-fold (0.08 log units) above what was measured, within the range that was stated.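

Placing 4-methyl-1,3-thiazol-2-yl instead of furan-3-yl on this aromatic carbon brings a 50-fold higher number from compound 2 to compound 3 (1.70 log units; beyond the scatter) in this assay and gives this position its first measured step. The change is not all-or-nothing, since compound 3 still has a measured value, but it alters the ring's hetero atoms and adds a methyl group at once, so no single feature can be credited. Nothing measured here accounts for the loss. The compounds shown leave open how a plain phenyl ring, an amine or a carboxylic acid would read at this position.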